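Replacing a bromophenyl by a methylphenyl in an amide series

A few compounds are considered here, and "the series" means these few. Any claim that something is new, unique, unknown or untested is made for them only; others in the source may bear on it.

Measured compounds:
Compound 1, `O=C(/C=C/c1cccc(NC(=O)c2ccccc2Br)c1)c1nc2ccccc2[nH]1`, 4520 nM
Compound 2, `O=C(Nc1cccc(/C=C/C(=O)c2nc3ccccc3[nH]2)c1)c1cccc(Br)c1`, 5210 nM
Compound 3, `O=C(Nc1cccc(/C=C/C(=O)c2nc3ccccc3[nH]2)c1)c1ccc(Br)cc1`, 7000 nM

The three compounds share one core and differ only in the aromatic ring attached to the amide carbonyl. In a functional assay on MCF7 cells (Homo sapiens) for antiproliferative activity, read by MTT assay, with a stated time of 48 h (on this read-out higher numbers stand for weaker inhibition and lower numbers for stronger inhibition), compound 3 gives 7000 nM, the highest of the three numbers, yet the step of a 1.3-fold higher number from compound 2 to compound 3 (0.13 log units; within the scatter) and the step of a 1.5-fold higher number from compound 1 to compound 3 (0.19 log units; within the scatter) both lie within the scatter, as does a 1.2-fold higher number from compound 1 to compound 2 (0.06 log units; within the scatter). Nothing among these compounds separates one bromophenyl from another.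

Compound 4, `Cc1cccc(C(=O)Nc2cccc(/C=C/C(=O)c3nc4ccccc4[nH]3)c2)c1`, carries the change (3-methylphenyl in place of 4-bromophenyl on a carbonyl carbon). Among the measured compounds shown here, no measured step bears directly on it: the three steps recorded cover only a move of the bromine around the ring, and all of them were within the scatter. Compound 4 is therefore expected to give a number close to that of compound 3, with a 1.2-fold lower number from compound 3 to compound 4 (0.07 log units; within the scatter) not beyond the scatter in either direction. The estimate for compound 4 in this assay is 6000 nM, with a range from 2500 nM to 15000 nM.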

Compound 4, half-maximal inhibitory concentration: 5590 nM
Estimate against measurement, compound 4: 1.1-fold (0.03 log units) above; low and high end bracket the measured number.
By their numbers in this assay, from the lowest: compounds 1, 2, 4 and 3 (each within the scatter of the next).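

In this assay, among the compounds shown here, methyl in place of bromo on an aromatic carbon makes no readable difference: a 1.1-fold higher number from compound 2 to compound 4 (0.03 log units; within the scatter) is the only new step confined to that exchange, and it lies within the scatter. The steps that also shift the substituent around the ring, a 1.3-fold lower number from compound 3 to compound 4 (0.10 log units; within the scatter) and a 1.2-fold higher number from compound 1 to compound 4 (0.09 log units; within the scatter), lie within the scatter too, so the separation is absent for methyl as well as for the bromine positions. No measurement is available that would account for this absence of a difference.

Every ring shown on this carbonyl carbon carries only bromo or methyl, so the effect of an amine or a carboxylic acid there remains open. Also open, on these data alone, is whether 2-methylphenyl or 4-methylphenyl would fall within the same narrow band of values.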